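The source may report more compounds than this note shows. Statements on the series, on what has been measured and on what is new or still open speak of the compounds shown alone.

Measured so far:

- compound 1 `CN1CCCC(NS(=O)(=O)c2ccccc2Nc2cc(-c3ccc4ccn(C)c4c3)c3nccnc3c2)C1` gives 0.483 h in an ADME assay on microsomes from liver (Mus musculus, strain CD-1) for metabolic stability, read by LC-MS, tested at 2 uM; a lower number here means that the compound disappears faster, a higher number that the compound lasts longer
- compound 2 `CN(C)C(=O)c1ccncc1Nc1cc(-c2ccc3ccn(C)c3c2)c2nccnc2c1` gives 0.35 h in this assay

Only two numbers stand in this assay, and they lie within the scatter of each other, so compound 2 and compound 1 are not distinguished on what has been measured; compound 2 simply sits at the level the shared core has shown so far. Among the measured compounds shown here, no step between two measured compounds that differ in a single place is available, so there is nothing yet to calibrate how a change at the carbonyl carbon moves the half-life.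

Compound 3 `CC(=O)N1CC(CNC(=O)c2ccncc2Nc2cc(-c3ccc4ccn(C)c4c3)c3nccnc3c2)C1` is the next one to be run in this assay. It differs from compound 2 in one place: ((1-acetylazetidin-3-yl)methyl)amino in place of dimethylamino on a carbonyl carbon. Without a measured step for a comparable change, the expectation rests on compound 2 alone, whose value 0.35 h is taken as the anchor. The step is expected to be small, with no direction that would carry it beyond the scatter, and a 1.1-fold higher number from compound 2 to compound 3 (0.06 log units; within the scatter) is the estimated step from compound 2 to compound 3. Compound 3 is estimated at 0.4 h, with a range from 0.2 h to 0.9 h.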

Compound 3, half-life: > 1 h
Compound 3: a limit, no number; the forecaster's own chance of this, stated with the estimate: 5%; middle value at least 2.5-fold (0.39 log units) away from the limit.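

In this assay, among the compounds shown here, ((1-acetylazetidin-3-yl)methyl)amino in place of dimethylamino on a carbonyl carbon gives an at least 2.8-fold higher number from compound 2 to compound 3 (0.45 log units; beyond the scatter), the first single-place step and one that lies beyond the scatter. This shows that the group on this carbonyl carbon can move the half-life by more than repeat measurements would, and that the change from dimethylamino to this larger group with a four-membered ring goes towards a longer-lasting compound. For compound 3 the reading is a limit of the assay and not a number, so the step has a lower bound but no measured size: the limit of > 1 h in this assay, at which 1 of the 3 values shown sits.

The change alters several things at once, so the data do not separate the contribution of the amide hydrogen, the azetidine ring and the acetyl group. Open questions are whether a plain methylamino on the same carbonyl carbon would already shift the half-life, and whether an azetidine carrying a free ring amine in place of the acetyl group would keep the step.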